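The source may hold more compounds than are shown below. What is called first, only, known or untested is meant among the compounds shown, and "the series" means these compounds.

Compound 1, `CCCCn1ccc(-c2ccc(Oc3ccnc(C)c3)cc2)c(C#N)c1=O`, gives 398 nM in a functional assay on CHO cells for positive allosteric modulation of metabotropic glutamate receptor 2 (Homo sapiens), read by scintillation counting and GTPgammaS binding, with a stated time of 30 min; on this read-out higher numbers stand for an effect only at larger amounts of compound and lower numbers for an effect already at smaller amounts. Compound 2, `Cc1cc(Oc2ccc(-c3ccn(CC4CC4)c(=O)c3C#N)cc2)ccn1`, gives 832 nM in this assay. Compound 3, `CCCCn1ccc(-c2ccc(Oc3cccnc3C)c(Cl)c2)c(C#N)c1=O`, gives 100 nM in this assay, the lowest of the three numbers.

Compound 4, `Cc1ncccc1Oc1ccc(-c2ccn(CC3CC3)c(=O)c2C#N)cc1Cl`, has not yet been measured in this assay. It differs from compound 3 by cyclopropyl in place of propyl on a saturated chain carbon bound to an aromatic nitrogen. The same change, (cyclopropyl in place of propyl on a saturated chain carbon bound to an aromatic nitrogen), separates compound 1 from compound 2, where it produced a 2.1-fold higher number from compound 1 to compound 2 (0.32 log units; beyond the scatter). The difference between the core of compound 1 and the core of compound 3 is not broken down here, but the place of the change is described in the same words for both pairs, so the change from compound 3 to compound 4 is the same change.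

Within the data shown here, with only one prior instance, the expectation rests on that single step. Among the measured compounds shown here, the step from compound 3 to compound 4 is expected to be a 2.1-fold higher number from compound 3 to compound 4 (0.32 log units; beyond the scatter), close to the one seen from compound 1 to compound 2. Compound 4 is therefore estimated at 210 nM in this assay, with a likely range from 100 nM to 450 nM.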

Compound 4, half-maximal effective concentration: 230 nM
Compound 4: middle estimate off by 1.1-fold (0.04 log units), on the low side; the range from low to high includes it.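

Replacing propyl with cyclopropyl on the core of compound 3 gave a 2.3-fold higher number from compound 3 to compound 4 (0.36 log units; beyond the scatter) in this assay, so the change moved the number in the same direction as it had on the core of compound 1. Set side by side, the two steps agree in size, and in this series the step measured on one core predicted the step on the other: the same change on two cores in this assay, a 2.1-fold higher number (0.32 log units; beyond the scatter) from compound 1 to compound 2 and a 2.3-fold higher number (0.36 log units; beyond the scatter) from compound 3 to compound 4, 1.1-fold (0.04 log units) apart, within the scatter of two such steps This shows that the change carried over between these two cores in this one assay, but it does not show that it would carry over to any other core, and it does not explain why the step has this size.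

The compounds shown leave open how other groups in the same place would behave, such as a longer chain, a cyclobutyl group or a chain ending in an amine. On these data alone, it also remains open whether the step would hold on a core with fluorine or a methoxy group in place of the chlorine of compound 3.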